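One Aryl Swap on a Shared Core

The source may hold more compounds than are shown below. What is called first, only, known or untested is meant among the compounds shown, and "the series" means these compounds.

Measured compounds:
Compound 1 `N#CC1=C(N)OC(c2c[nH]c3ccccc23)=C(C#N)C1c1ccc(Br)cc1`: 14.2%
Compound 2 `N#CC1=C(N)OC(c2c[nH]c3ccccc23)=C(C#N)C1c1ccc2ccccc2c1`: "not active" (no number reported)
Compound 3 `COc1ccc(C2C(C#N)=C(N)OC(c3c[nH]c4ccccc34)=C2C#N)cc1OC`: 14.5%

In a functional assay, tested at 50 ug/mL (on this read-out higher numbers stand for a stronger effect at the one concentration tested and lower numbers for a weaker effect), compound 3 gives 14.5%. For the measured compounds named here, only two numbers exist here, and compound 3 and compound 1 sit within the usual scatter of each other; compound 2 returned no number at all. Going by the values given here, the single measured step that changes the same place, a number 0.3 percentage points higher from compound 1 to compound 3 (within the scatter), is within the scatter, so exchanging one aryl group for another on this saturated ring carbon has so far left the read-out essentially unchanged.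

Compound 4 `CN(C)c1ccc(C2C(C#N)=C(N)OC(c3c[nH]c4ccccc34)=C2C#N)cc1` is the next variation at that same place: 4-(dimethylamino)phenyl in place of 3,4-dimethoxyphenyl on a saturated ring carbon. Among the compounds with values here, because the one comparable step, a number 0.3 percentage points higher from compound 1 to compound 3 (within the scatter), was within the scatter, no movement beyond the scatter is expected in either direction. The expected step is a number 0.5 percentage points lower from compound 3 to compound 4 (within the scatter). Compound 4 is therefore estimated to give about 14%, with a range from 4% to 26%, while the silent result of compound 2 leaves some chance of no number at all.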

Compound 4, a percentage reported as activity, at one concentration (the size of the read-out at that concentration, not a potency): 14.4%
For compound 4 the middle estimate is 0.4 percentage points below the measured one; measured number inside the range.
By their numbers in this assay, from the lowest: compounds 1, 4 and 3 (each within the scatter of the next).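

Placing 4-(dimethylamino)phenyl on the saturated ring carbon gives a number 0.1 percentage points lower from compound 3 to compound 4 (within the scatter) when it replaces 3,4-dimethoxyphenyl, and a number 0.2 percentage points higher from compound 1 to compound 4 (within the scatter) when dimethylamino replaces bromo on the aromatic carbon. In this assay, three different substituted phenyl groups at this place now give numbers within the scatter of one another, including one whose entering group carries nitrogen, although compound 2 goes against this picture by returning no number. No measurement here offers an explanation for this flat result.

Going by these compounds, it remains open whether a carboxylic acid on the phenyl ring, or a butyl chain in place of the whole aryl group, would separate from these numbers. The single test concentration also leaves open how these compounds would compare at other concentrations.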